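One More Double Bond in the Lactone Tail

This account rests on a few compounds, and the source may have more. Where it says the series, first, only, none or still open, it means among the compounds named here.

Three macrolactones have been tested in a functional assay on A549 cells (Homo sapiens) for cytotoxicity; a higher number here means that more compound is needed for the effect, a lower number that less compound is needed. Compound 1 `CCCCC/C=C\C[C@@H]1O[C@@H]1/C=C/[C@@H]1C/C=C\CCCC(=O)O1` gives 4.8 ug/mL. Compound 2 `CC/C=C\C/C=C\C[C@@H](O)[C@H](O)/C=C/[C@@H]1C/C=C\CCCC(=O)O1` gives 4.7 ug/mL. Compound 3 `CCCCC/C=C\C[C@H](O)C(/C=C/[C@@H]1C/C=C\CCCC(=O)O1)OC` gives 5.2 ug/mL, the highest of the three numbers, although its gaps to compound 1 and to compound 2 both lie within the usual scatter, so the three cannot be told apart. Compound 4 `CC/C=C\C/C=C\C[C@H](O)C(/C=C/[C@@H]1C/C=C\CCCC(=O)O1)OC` has not been measured; it differs from compound 3 in one place: but-1-en-1-yl in place of butyl on a saturated chain carbon bound to a double-bonded chain carbon. Compound 1 and compound 2 differ in this tail too, among other things, and their values sit within the scatter of each other. No step beyond the scatter is therefore expected in this assay. Compound 4 is estimated at 5 ug/mL, within 2.5 ug/mL to 10 ug/mL. This corresponds to an expected step of a 1.0-fold lower number from compound 3 to compound 4 (0.02 log units; within the scatter).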

Compound 4, concentration for half-maximal effect: 4.8 ug/mL
The estimate for compound 4 lay 1.0-fold (0.02 log units) above the measured number; the range from low to high includes it.
By their numbers in this assay, from the lowest: compounds 2, 1, 4 and 3 (each within the scatter of the next).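

Replacing butyl with but-1-en-1-yl on a saturated chain carbon bound to a double-bonded chain carbon gives a 1.1-fold lower number from compound 3 to compound 4 (0.03 log units; within the scatter) in this assay. For the compounds shown here, compounds 1 and 2 differ in more than this tail, so this pair is the first to isolate the extra double bond, and it produces no change that can be told from the scatter. No available measurement bears on this result. On these data alone, whether an amine, a carboxylic acid or a longer chain in place of butyl would also leave the number within the scatter remains open.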